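The compounds below may be only part of what the source reports. "The series", "measured", "known", "first", "only" and "open" are said of these compounds alone.

In a functional assay on MCF7 cells (Homo sapiens) for inhibition, read by MTT assay, with a stated time of 72 h (a higher number here means a weaker inhibitor, a lower number a stronger inhibitor), compound 1 `O=C(Nc1ccccc1)C1CCN(C/C=C/c2ccccc2)CC1` gives 60200 nM, so a high concentration is needed to inhibit the cells. Compound 2 `COc1ccc(NC(=O)C2CCN(C/C=C/c3ccccc3)CC2)cc1` is reported as > 100000 nM, which is a limit of the assay and not a number. Compound 2 therefore has no exact position on the scale.

The next compound keeps the same atoms but joins them differently. Compound 3 `COc1cccc(NC(=O)C2CCN(C/C=C/c3ccccc3)CC2)c1` has 3-methoxyphenyl in place of 4-methoxyphenyl on an amide-type nitrogen.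

Within the data shown here, only one measured step bears on this change, and it adds a methoxy rather than moving one. That step is an at least 1.6-fold higher number from compound 1 to compound 2 (0.22 log units; that floor lies within the scatter). Among the measured compounds shown here, it gives a floor and not a true size, and no measured step shows what moving the methoxy does. The best guide is therefore compound 1 at 60200 nM, and no large gain in this assay is expected. The expected step is an at least 1.3-fold lower number from compound 2 to compound 3 (0.12 log units; that floor lies within the scatter), a modest move towards a lower number that remains uncertain. A report of only a limit is also quite possible. Compound 3 is estimated at 75000 nM, with an expected range from 30000 nM to 150000 nM.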

Compound 3, half-maximal inhibitory concentration: 42700 nM
Estimate against measurement, compound 3: 1.8-fold (0.24 log units) above, within the range that was stated.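

Moving the methoxy from 4-methoxyphenyl to 3-methoxyphenyl on the amide-type nitrogen gives an at least 2.3-fold lower number from compound 2 to compound 3 (0.36 log units; beyond the scatter) in this assay and so shows that where the methoxy sits on this ring makes a difference, which the earlier step, with its floor inside the scatter, could not show. That step is only a floor because compound 2 is reported at a limit of the assay and not at a number: the limit of > 100000 nM in this assay, at which 1 of the 3 values shown sits. Adding the methoxy as 3-methoxyphenyl gives a 1.4-fold lower number from compound 1 to compound 3 (0.15 log units; within the scatter) and so brings no change beyond the scatter, which means the gap in this pair comes with the 4-methoxyphenyl compound and not with a gain over the plain phenyl ring.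

The compounds shown leave open whether this sensitivity belongs to the methoxy itself or would also appear with another group on the same ring, such as a fluorine, a hydroxyl or an amine. They also leave open how far the number could move with a change elsewhere on the shared core, such as a carboxylic acid on the other phenyl ring.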